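The compounds below may be only part of what the source reports. "The series", "measured", "known", "first", "only" and "open" are said of these compounds alone.

Of the compounds shown here, two built on one shared core have been measured in a physicochemical assay for solubility, read by HPLC; a lower number here means a less soluble compound, a higher number a more soluble compound. Compound 1 `O=C(c1ccccc1F)N1CCN(c2nc(=O)c3cc(C(F)(F)F)cc([N+](=O)[O-])c3s2)CC1` carries a 2-fluorophenyl on a carbonyl carbon, and in this assay compound 1 gives 3.1 ug/mL. Compound 2 `CC(C)(C)C1CCC(C(=O)N2CCN(c3nc(=O)c4cc(C(F)(F)F)cc([N+](=O)[O-])c4s3)CC2)CC1` carries a 4-(tert-butyl)cyclohexyl in that place instead. For compound 2 the read-out is < 0.1 ug/mL, which is a limit of the assay rather than a number (the limit of < 0.1 ug/mL in this assay, at which 1 of the 2 values shown sits). Among the compounds with values here, the one measured step, an at least 31-fold lower number from compound 1 to compound 2 (1.49 log units; beyond the scatter), ran strongly downward in this assay when the 4-(tert-butyl)cyclohexyl entered.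

Compound 3 `CC(=O)N1CCN(c2nc(=O)c3cc(C(F)(F)F)cc([N+](=O)[O-])c3s2)CC1` has not yet been measured. It differs from compound 2 in one place: methyl in place of 4-(tert-butyl)cyclohexyl on a carbonyl carbon. Within the data shown here, the step of an at least 31-fold lower number from compound 1 to compound 2 (1.49 log units; beyond the scatter) is the only measured change that bears on this, and it was large. Taking the 4-(tert-butyl)cyclohexyl out again in favour of methyl is expected to move the number upward by a large margin, so compound 3 is estimated at 15 ug/mL, within 3 ug/mL to 60 ug/mL, a step of an at least 150-fold higher number from compound 2 to compound 3 (2.17 log units; beyond the scatter).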

Compound 3, solubility: 83.9 ug/mL
Estimate against measurement, compound 3: 5.6-fold (0.75 log units) below, and the stated range ends below it.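

With methyl on this carbonyl carbon, the number in this assay rises past that of the 2-fluorophenyl, with a 27-fold higher number from compound 1 to compound 3 (1.43 log units; beyond the scatter), so compound 1 no longer marks the top of the range seen at this position. Methyl in place of 4-(tert-butyl)cyclohexyl gives an at least 830-fold higher number from compound 2 to compound 3 (2.92 log units; beyond the scatter), and among the three groups shown, the acetyl of compound 3 gives the highest number and the (4-(tert-butyl)cyclohexyl)carbonyl of compound 2 the lowest. Compound 2 stands at a limit of the assay rather than at a number: the limit of < 0.1 ug/mL in this assay, at which 1 of the 3 values shown sits.

Three groups cannot show whether the number follows the size of the group, the presence of a ring, or something else, and an ethyl, a longer chain, an amine or a carboxylic acid at this place could fall anywhere. On these data alone, whether the same order of groups holds on a different core also stays open.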